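Expecting Little from a Third Methyl on Compound 1

The source may hold more compounds than are shown below. What is called first, only, known or untested is meant among the compounds shown, and "the series" means these compounds.

In a functional assay on the whole organism with Mus musculus as the target (on this read-out lower numbers stand for lower potency and higher numbers for higher potency (the scale is a negative logarithm)), compound 1 `Cc1ccc(C)c(C(=O)OC2CCN(C)CC2)c1` gives 1.36. Two other compounds built on the same core were measured in the same way: compound 2 `CN1CCC(OC(=O)c2ccccc2C(F)(F)F)CC1` gives 1.49, and compound 3 `CN1CCC(OC(=O)c2cccc(C#N)c2)CC1` gives 1.39. Among these three numbers compound 1 holds the lowest, but the nearest, that of compound 3, lies within the usual scatter of repeated measurements, and so does the furthest, that of compound 2. The three compounds therefore cannot be told apart on this read-out.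

Compound 4 `Cc1cc(C)c(C(=O)OC2CCN(C)CC2)cc1C` has not yet been measured in this assay. It differs from compound 1 in one place: methyl in place of hydrogen on an aromatic carbon. Within the data shown here, no step between two measured compounds of this kind is available, so the size of the step can only be judged from the general picture. Since all three measured compounds sit close together although they carry different groups on the aromatic ring, one more methyl group is expected to move the number little, and the expected step is a number 0.09 log units higher from compound 1 to compound 4 (within the scatter), with no direction beyond the scatter. For compound 4 the estimated value in this assay is 1.45, ranging from 1.15 to 1.75.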

Compound 4, logarithm of the reciprocal of the active concentration, log(1/C): 1.17
Compound 4: middle estimate off by 0.28 log units, on the high side; measured number inside the range.
By their numbers in this assay, from the lowest: compounds 4, 1, 3 and 2 (each within the scatter of the next, the first and the last beyond it).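

Swapping hydrogen for methyl on this aromatic carbon, which is ortho to a methyl group, meta to a methyl group and para to a large group, gives the first step in this set that changes only one place. The step in this assay is a number 0.19 log units lower from compound 1 to compound 4 (within the scatter) and so cannot be told apart from repeated measurement of a single compound, which means that this position takes one extra methyl group with no readable change in the number. The earlier compounds could only hint at this through their different groups, whereas this pair isolates a single carbon, although nothing available explains the size of this step.

From the compounds shown here alone, whether a larger or different group on this same carbon, such as an ethyl group, a methoxy group or an amine, would produce a step beyond the scatter remains open. Also open, going by these compounds, is whether methyl in place of hydrogen on the other aromatic carbons of compound 1 would behave as it does here, since one step speaks for one position only.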